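Amino to bromo on the pendant phenyl: what to expect

This account rests on a few compounds, and the source may have more. Where it says the series, first, only, none or still open, it means among the compounds named here.

The three measured compounds share one core: compound 1 `O=[N+]([O-])c1cccc(CNc2cc(C(F)(F)F)cc3[nH]ncc23)c1`, compound 2 `FC(F)(F)c1cc(NC[C@@H]2CCCCN2)c2cn[nH]c2c1` and compound 3 `Nc1cccc(CNc2cc(C(F)(F)F)cc3[nH]ncc23)c1`. In an assay for inhibition of Indoleamine 2,3-dioxygenase 1 (Homo sapiens), with stated times of 10 min and 60 min, tested at 100 uM (a higher number here means a stronger effect of the compound at the concentration tested, a lower number a weaker effect), compound 1 gives 69%, compound 2 gives 81% and compound 3 gives 55%. Compound 3 thus stands lowest of the three numbers, compound 1 nearest and compound 2 furthest. Going by the values given here, the steps so far are a number 14 percentage points lower from compound 1 to compound 3 (beyond the scatter) and a number 26 percentage points lower from compound 2 to compound 3 (beyond the scatter), both beyond the scatter. Compound 4 `FC(F)(F)c1cc(NCc2cccc(Br)c2)c2cn[nH]c2c1` is still unmeasured; its difference from compound 3 is bromo in place of amino on an aromatic carbon. Bromo appears in no measured compound, so only the step ending at compound 3 bears on it, and only loosely: read in reverse, replacing the amino raised the number. A modest rise is therefore expected, a number 11 percentage points higher from compound 3 to compound 4 (beyond the scatter). The estimate for compound 4 is 66%, within 48% to 84%.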

Compound 4, a percentage reported as inhibition, at one concentration (the size of the read-out at that concentration, not a potency): 51%
Beside the measured number, compound 4's estimate is 15 percentage points above it; the range from low to high includes it.
By their numbers in this assay, from the lowest: compounds 4 and 3 (each within the scatter of the next); then compound 1; then compound 2.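

In this assay, bromo in place of amino gives a number 4 percentage points lower from compound 3 to compound 4 (within the scatter) and so shows that, on this aromatic carbon, losing amino's hydrogen-bond donor and acceptor does not by itself separate the two groups. Bromo in place of nitro is a different matter, with a number 18 percentage points lower from compound 1 to compound 4 (beyond the scatter) at the same carbon, and 3-bromophenyl in place of piperidin-2-yl gives a number 30 percentage points lower from compound 2 to compound 4 (beyond the scatter) on the saturated chain carbon. No measurement at hand explains these steps.

Going by these compounds, whether a carboxylic acid or a methoxy group on this carbon would stand apart from amino and bromo remains open. So does whether a longer chain carrying the 3-bromophenyl would change the read-out.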